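Replacing 4-fluorophenyl in a two-compound series

A few compounds are considered here, and "the series" means these few. Any claim that something is new, unique, unknown or untested is made for them only; others in the source may bear on it.

Measured in a functional assay on MCF7 cells (Homo sapiens) for inhibition, read by MTT assay, with a stated time of 48 h; on this read-out lower numbers stand for stronger inhibition of growth and higher numbers for weaker inhibition of growth:
- compound 1 `COc1cc(C2=NN(C(=O)c3cccnc3)C(c3cn(C)c4ccc(Br)cc34)C2)cc(OC)c1OC` gives > 10000 nM (a limit of the assay)
- compound 2 `COc1ccc2c(c1)c(C1CC(c3ccc(F)cc3)=NN1C(=O)c1ccc(OC)nc1)cn2C` gives 480 nM

Compound 1 is recorded at > 10000 nM, which is a limit and not a number. Among the measured compounds shown here, compound 2, at 480 nM, holds the only numerical value so far, so it is the sole anchor for any estimate.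

The next compound to be read is compound 3 `COc1cccc(C2=NN(C(=O)c3ccc(OC)nc3)C(c3cn(C)c4ccc(OC)cc34)C2)c1`. It has 3-methoxyphenyl in place of 4-fluorophenyl on a carbon with a double bond to nitrogen, and the rest of compound 2 is kept: 3-methoxyphenyl in place of 4-fluorophenyl on a carbon with a double bond to nitrogen.

For the measured compounds named here, no step between measured compounds is available to size this change, so the expectation is loose. In this assay a modest weakening of growth inhibition is expected, and a result close to compound 2 would not be surprising. The expected change is a 1.7-fold higher number from compound 2 to compound 3 (0.22 log units; within the scatter). For compound 3 the estimated value is 800 nM, with an expected range from 150 nM to 4000 nM.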

Compound 3, concentration for 50% growth inhibition: 130 nM
Compound 3: the middle estimate sits 6.2-fold (0.79 log units) above what was measured; measured number outside the range, below it.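

In this assay, the place on the carbon with a double bond to nitrogen of the five-membered non-aromatic ring proves sensitive to the choice of aryl group, with 3-methoxyphenyl in place of 4-fluorophenyl giving a 3.7-fold lower number from compound 2 to compound 3 (0.57 log units; beyond the scatter). Among the compounds shown here, this is the first step that can be sized, and because it lies beyond the scatter, it shows that 4-fluorophenyl is not the better of these two groups when the rest of compound 2 is kept. No measured property of either group is available to account for this difference.

A single step swaps both the substituent and where it sits on the phenyl ring, so it cannot separate the loss of fluorine from the gain of methoxy, and 4-methoxyphenyl and 3-fluorophenyl would be needed to pull those apart. Also open, as far as these compounds go, is how far this place accepts other kinds of group, such as a 3-dimethylaminophenyl, a 3-carboxyphenyl or a simple unsubstituted phenyl, and whether the step carries over to other cell lines or to the other parts of the shared core.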